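Swapping a Cyanophenyl for a Methylphenyl

The compounds below may be only part of what the source reports. "The series", "measured", "known", "first", "only" and "open" are said of these compounds alone.

Three compounds share one core and differ only in the aryl group on an aromatic nitrogen. In a functional assay on A549 cells (Homo sapiens) for inhibition, read by MTT assay, with a stated time of 24 h (a higher number here means a weaker inhibitor, a lower number a stronger inhibitor), compound 1 `CC1(C)[C@H]2CC[C@]1(C)N(Cc1cn(-c3cccc(F)c3)nn1)C(=O)C2` gives 180 nM, compound 2 `CC1(C)[C@H]2CC[C@]1(C)N(Cc1cn(-c3cccc(C#N)c3)nn1)C(=O)C2` gives 440 nM, and compound 3 `CC1(C)[C@H]2CC[C@]1(C)N(Cc1cn(-c3ccc(Br)cc3)nn1)C(=O)C2` gives 80 nM. Compound 2 therefore has the highest number of the three, making it the weakest inhibitor here. Compound 4 `Cc1ccc(-n2cc(CN3C(=O)C[C@@H]4CC[C@@]3(C)C4(C)C)nn2)cc1` is compound 2 with 4-methylphenyl in place of 3-cyanophenyl on an aromatic nitrogen. Within the data shown here, two measured steps bear on this: a 5.5-fold lower number from compound 2 to compound 3 (0.74 log units; beyond the scatter), and a 2.4-fold higher number from compound 1 to compound 2 (0.39 log units; beyond the scatter). Among the measured compounds shown here, both point toward a lower number once the cyano leaves, though a methyl group itself has no measured precedent. The step is therefore expected to be a 2.9-fold lower number from compound 2 to compound 4 (0.47 log units; beyond the scatter). Compound 4 is estimated at 150 nM, within a range of 60 nM to 400 nM.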

Compound 4, half-maximal inhibitory concentration: 400 nM
Estimate against measurement, compound 4: 2.7-fold (0.43 log units) below; low and high end bracket the measured number.
By their numbers in this assay, from the lowest: compound 3; then compound 1; then compounds 4 and 2 (each within the scatter of the next).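

Dropping the nitrile was not enough on its own: 4-methylphenyl in place of 3-cyanophenyl gives a 1.1-fold lower number from compound 2 to compound 4 (0.04 log units; within the scatter), so compound 4 stays level with compound 2. Methyl in place of bromo on an aromatic carbon gives a 5.0-fold higher number from compound 3 to compound 4 (0.70 log units; beyond the scatter), and 4-methylphenyl in place of 3-fluorophenyl gives a 2.2-fold higher number from compound 1 to compound 4 (0.35 log units; beyond the scatter). The low number of compound 3 therefore goes with the bromo itself, not with the mere absence of a nitrile.

Nothing shown gives a reason for these differences. On these data alone, whether a chloro or a methoxy group in that place would follow bromo or methyl remains open.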